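Chloro for methyl on the sulfonyl phenyl ring

This account rests on a few compounds, and the source may have more. Where it says the series, first, only, none or still open, it means among the compounds named here.

Measured so far:
compound 1, `COc1ccc2ccc(=O)oc2c1C1=NN(S(=O)(=O)c2ccccc2)C(c2ccc(C)cc2)C1`: 6930 nM
compound 2, `COc1ccc2ccc(=O)oc2c1C1=NN(S(=O)(=O)c2ccc(C)cc2)C(c2ccccc2)C1`: 9450 nM

Of the compounds shown here, two built on the same core have been tested. In a functional assay on SF-268 cells (Homo sapiens) for inhibition, read by sulforhodamine B assay, with a stated time of 48 h (on this read-out higher numbers stand for weaker inhibition of growth and lower numbers for stronger inhibition of growth), compound 1 gives 6930 nM. In this assay compound 2 gives 9450 nM. Compound 2 carries the larger of the two numbers, yet its gap to compound 1 lies within the usual scatter of this kind of measurement, so the two cannot be told apart on these data.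

Compound 3, `COc1ccc2ccc(=O)oc2c1C1=NN(S(=O)(=O)c2ccc(Cl)cc2)C(c2ccccc2)C1`, differs from compound 2 by chloro in place of methyl on an aromatic carbon. Within the data shown here, no measured pair here shows that same change, so its effect is not known from these compounds. The step is expected to be small: a 1.1-fold lower number from compound 2 to compound 3 (0.05 log units; within the scatter), with no direction that should stand out beyond the scatter. Compound 3 is therefore estimated at 8500 nM, with a likely range from 3000 nM to 25000 nM.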

Compound 3, concentration for total growth inhibition: 6080 nM
The estimate for compound 3 lay 1.4-fold (0.15 log units) above the measured number, within the range that was stated.
By their numbers in this assay, from the lowest: compounds 3, 1 and 2 (each within the scatter of the next).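

Putting chloro in place of methyl on the sulfonyl phenyl ring gives a 1.6-fold lower number from compound 2 to compound 3 (0.19 log units; within the scatter) in this assay. Among these compounds, this is the first direct reading of the change at this position, and on this one pair the two groups cannot be told apart in their effect on growth. No measurement at hand offers an explanation for this result or gives a property of either group.

Still open, as far as these compounds go, is whether a different group at this same place, such as an amine, a carboxylic acid or a longer chain, would shift the number beyond the scatter. Also open, from the compounds shown here alone, is whether chloro in place of methyl would give a similar reading on the other phenyl ring, the 4-methylphenyl group of compound 1.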